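A Small Swap on a Weakly Active Scaffold

This account rests on a few compounds, and the source may have more. Where it says the series, first, only, none or still open, it means among the compounds named here.

Of the compounds shown here, two have so far been tested in a functional assay on U-373MG ATCC cells (Homo sapiens) for inhibition, read by MTT assay, with a stated time of 72 h; a lower number here means a stronger inhibitor, a higher number a weaker inhibitor. Compound 1 `O=[N+]([O-])c1ccc(NC(=S)NCc2cccc(Cl)c2)cc1` gives 27000 nM. Compound 2 `CC1(C)CC(NC(=O)Nc2ccccc2)c2cc(Cl)ccc2O1` gives 68000 nM, the higher of the two numbers, and its gap from compound 1 lies beyond the usual scatter. Compound 3 `CCOC(=O)NC1CC(C)(C)Oc2ccc(Cl)cc21` keeps the core of compound 2 but carries ethoxy in place of anilino on a carbonyl carbon. For the measured compounds named here, no measured pair shows what such a change does here, so only a modest step is expected, a 1.3-fold higher number from compound 2 to compound 3 (0.12 log units; within the scatter), possibly none beyond the scatter. Compound 3 is therefore estimated at 90000 nM, with a likely range from 30000 nM to 250000 nM.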

Compound 3, half-maximal inhibitory concentration: > 100000 nM
Compound 3: no number, only a limit; the forecaster's own chance of this, stated with the estimate: 35%; at least 1.1-fold (0.04 log units) between middle value and limit.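

At this position, ethoxy in place of anilino on a carbonyl carbon gives an at least 1.4-fold higher number from compound 2 to compound 3 (0.16 log units; that floor lies within the scatter). Compound 3 has no exact number, only a limit of the assay: the limit of > 100000 nM in this assay, at which 1 of the 3 values shown sits. The swap therefore shows no sign of a stronger inhibitor, but whether it truly weakens the compound remains unsettled.

The compounds shown leave open whether a benzylamine or a simple dimethylamine on the carbonyl carbon would give a lower number than compound 2. They also leave open whether a longer chain in place of ethoxy would change the result.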